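The source may report more compounds than this note shows. Statements on the series, on what has been measured and on what is new or still open speak of the compounds shown alone.

Compound 1 `CC[C@@H]1C(=O)N(C)c2cnc(-n3ccc4cc(C(=O)NC(C)C)ccc43)nc2N1C1CCCC1` gives 1840 nM in a functional assay on NCI-H1975 cells (Homo sapiens) for antiproliferative activity, read by CCK-8 assay, with a stated time of 72 h; on this read-out lower numbers stand for stronger inhibition of growth and higher numbers for weaker inhibition of growth. Compound 2 `CC[C@@H]1C(=O)N(C)c2cnc(-n3ccc4cc(C(=O)NC5CCCC5)ccc43)nc2N1C1CCCC1` gives 856 nM in this assay, and compound 3 `CC[C@@H]1C(=O)N(C)c2cnc(-n3ccc4cc(C(N)=O)ccc43)nc2N1C1CCCC1` gives 3380 nM, the highest of the three numbers; its steps from the other two are a 1.8-fold higher number from compound 1 to compound 3 (0.26 log units; within the scatter) and a 3.9-fold higher number from compound 2 to compound 3 (0.60 log units; beyond the scatter). Compound 4 `CC[C@@H]1C(=O)N(C)c2cnc(-n3ccc4ccccc43)nc2N1C1CCCC1` goes one place further: hydrogen in place of carbamoyl on an aromatic carbon. Within the data shown here, no measured step removes the carbamoyl itself; the two that alter the group on its amide-type nitrogen bear only indirectly, and of them only a 3.9-fold higher number from compound 2 to compound 3 (0.60 log units; beyond the scatter) is beyond the scatter, pointing to a higher number as that group is taken away. On that basis compound 4 is expected to give 6500 nM, range 2500 nM to 16000 nM, an expected step of a 1.9-fold higher number from compound 3 to compound 4 (0.28 log units; within the scatter) that would lie beyond the scatter.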

Compound 4, concentration for 50% growth inhibition: 28300 nM
The estimate for compound 4 lay 4.4-fold (0.64 log units) below the measured number; the whole stated range lies below it.
By their numbers in this assay, from the lowest: compound 2; then compounds 1 and 3 (each within the scatter of the next); then compound 4.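

Taking the whole carbamoyl off the aromatic carbon shows that this position does not tolerate bare hydrogen in this assay (an 8.4-fold higher number from compound 3 to compound 4 (0.92 log units; beyond the scatter)). The same loss appears from the substituted amides (a 15-fold higher number from compound 1 to compound 4 (1.19 log units; beyond the scatter)) and (a 33-fold higher number from compound 2 to compound 4 (1.52 log units; beyond the scatter)), so all three amides stand well apart from hydrogen, which the changes on the amide-type nitrogen could not show. Nothing available here explains this result. From the compounds shown here alone, it remains open whether the carbonyl or the amide hydrogen matters more. Going by these compounds, it also remains open whether a nitrile, a carboxylic acid or a longer chain on the nitrogen would serve at this place.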